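Cytotoxicity notes on a thienyl-benzothiazole imine series

A few compounds are considered here, and "the series" means these few. Any claim that something is new, unique, unknown or untested is made for them only; others in the source may bear on it.

Measured compounds:
compound 1 `Oc1ccccc1/C=N/c1sc2c(c1-c1nc3ccccc3s1)CCC2`, 100 ug/mL
compound 2 `C(=C/c1ccccc1)\C=N\c1sc2c(c1-c1nc3ccccc3s1)CCC2`, 122 ug/mL
compound 3 `C(=C/c1ccccc1)\C=N\c1sc2c(c1-c1nc3ccccc3s1)CCCC2`, 207 ug/mL

In an ADME assay on cells (Rhabdomyosarcoma cell, Homo sapiens) for cytotoxicity, read by MTT assay, with a stated time of 72 h (a higher number here means that more compound is tolerated, a lower number that less compound is tolerated), compound 1 gives 100 ug/mL and compound 2 gives 122 ug/mL; the change between them is 2-hydroxyphenyl in place of 2-phenylethenyl on a carbon with a double bond to nitrogen, and the step is a 1.2-fold lower number from compound 2 to compound 1 (0.09 log units; within the scatter). Compound 3 gives 207 ug/mL in this assay; the difference between the cores of compound 2 and compound 3 is not broken down here.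

Compound 4 `Oc1ccccc1/C=N/c1sc2c(c1-c1nc3ccccc3s1)CCCC2` is not yet measured. It carries the change 2-hydroxyphenyl in place of 2-phenylethenyl on a carbon with a double bond to nitrogen on the core of compound 3, the same change as from compound 2 to compound 1. Because a 1.2-fold lower number from compound 2 to compound 1 (0.09 log units; within the scatter) was small, the expected step of a 1.2-fold lower number from compound 3 to compound 4 (0.09 log units; within the scatter) is also small. Compound 4 is therefore expected to give about 170 ug/mL in this assay, between 90 ug/mL and 320 ug/mL.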

Compound 4, half-maximal cytotoxic concentration: 42.4 ug/mL
Compound 4: the middle estimate sits 4.0-fold (0.60 log units) above what was measured; the measured number lies below the stated range.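

In this assay, 2-hydroxyphenyl in place of 2-phenylethenyl gives a 4.9-fold lower number from compound 3 to compound 4 (0.69 log units; beyond the scatter), and the same change does not have the same size on the two cores: the same change on two cores in this assay, a 1.2-fold lower number (0.09 log units; within the scatter) from compound 2 to compound 1 and a 4.9-fold lower number (0.69 log units; beyond the scatter) from compound 3 to compound 4, 4.0-fold (0.60 log units) apart, beyond the scatter of two such steps

A step read on one core is therefore a poor guide to the size of the step on the other in this series. Two pairs do not show what sets the difference, and they give no rule for any further core.

The compounds shown leave open how a plain phenyl or a 2-methoxyphenyl group would behave on the carbon with a double bond to nitrogen on these two cores. On these data alone, whether the gap between the steps also appears with such groups remains unknown.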